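Carboxy tail of compound 3 moved onto a phenoxy link

The source may hold more compounds than are shown below. What is called first, only, known or untested is meant among the compounds shown, and "the series" means these compounds.

Measured so far in an assay on isolated protein for agonist activity at Bile acid receptor (Homo sapiens), read by AlphaScreen, with a stated time of 30 min; a higher number here means that more compound is needed for the effect, a lower number that less compound is needed:
compound 1 `Cc1ccccc1-n1nc(C)c2c1NC(=O)[C@H](C)S[C@@H]2c1ccc(-c2ccccc2)cc1` gives 990 nM
compound 2 `COc1ccc(Oc2ccc([C@H]3S[C@@H](C)C(=O)Nc4c3c(C)nn4-c3ccccc3C)cc2)cc1` gives 2200 nM
compound 3 `Cc1ccccc1-n1nc(C)c2c1NC(=O)[C@H](C)S[C@@H]2c1ccc(-c2ccc(C(=O)O)cc2)cc1` gives "not active" (no number reported)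

Compound 3 stands outside the measured scale: it carries a 4-carboxyphenyl group on the shared core and is reported only as not active, so it has no number to set a step from. Compound 4 `Cc1ccccc1-n1nc(C)c2c1NC(=O)[C@H](C)S[C@@H]2c1ccc(Oc2ccc(C(=O)O)cc2)cc1` differs from compound 3 in one place: 4-carboxyphenoxy in place of 4-carboxyphenyl on an aromatic carbon.

Going by the values given here, only one measured step bears on this change, and only loosely. Going from a phenyl to a 4-methoxyphenoxy group gave a 2.2-fold higher number from compound 1 to compound 2 (0.35 log units; beyond the scatter), a modest shift. That step swaps a direct aryl link for an aryloxy link, as compound 3 to compound 4 does, but its end groups differ, and compound 3 itself is inactive rather than merely weak, so the step cannot be scaled onto it.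

Among the compounds with values here, with no starting number and no close analogue carrying the carboxylic acid through the phenoxy link, the expectation for compound 4 is that it also shows little or no activity in this assay, with a number, if any, far above the values of compound 1 and compound 2. Compound 4 is estimated at 15000 nM, in the range 3000 nM to 60000 nM, with a high chance that only an inactive call is returned.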

Compound 4, half-maximal effective concentration: "not active" (no number reported)
For compound 4 the study gives words and no number; no gap can be computed for the estimate.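

Compound 3 and compound 4 are both reported only as not active in this assay, so no step can be read between them. Nothing shown accounts for this result. The compounds shown leave open whether any carboxy-bearing group on the shared core can give a measurable number in this assay.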